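Replacing the trihydroxyphenyl group in compound 1: working notes

The source may report more compounds than this note shows. Statements on the series, on what has been measured and on what is new or still open speak of the compounds shown alone.

Values in a functional assay on DU-145 cells (Homo sapiens) for inhibition, read by trypan blue exclusion, with a stated time of 96 h (a higher number here means a weaker inhibitor of growth, a lower number a stronger inhibitor of growth), for the measured compounds
- compound 1 `O=C(/C(=C\c1c(O)cc(O)cc1O)SCc1ccc(Cl)cc1)c1ccc(Cl)cc1` gives > 100000 nM as a limit
- compound 2 `O=C(/C(=C\c1c(O)cc(O)cc1O)SCc1ccc(Cl)c(Cl)c1)c1ccc(Cl)cc1` gives 25000 nM
- compound 3 `O=C(/C(=C\c1c(O)cc(O)cc1O)Sc1ccc(Br)cc1)c1ccc(Cl)cc1` gives 50000 nM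

Compound 1 has no number, only the limit of > 100000 nM in this assay, at which 1 of the 3 values shown sits, and nothing firmer is known of where it stands.

For the measured compounds named here, the change to compound 4 `O=C(/C(=C\c1cccc(Cl)c1Cl)SCc1ccc(Cl)cc1)c1ccc(Cl)cc1` is 2,3-dichlorophenyl in place of 2,4,6-trihydroxyphenyl on a double-bonded chain carbon bound to a double-bonded chain carbon and no measured step touches that place. The measured steps all lie elsewhere in the molecule, in the group on the sulfur. They are an at least 4.0-fold lower number from compound 1 to compound 2 (0.60 log units; beyond the scatter) and an at least 2.0-fold lower number from compound 1 to compound 3 (0.30 log units; that floor lies within the scatter) and a 2.0-fold higher number from compound 2 to compound 3 (0.30 log units; within the scatter) and only the first of these clears the scatter. They therefore set no direct size for the new step, and serve only as a loose guide.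

A lower number in this assay is expected for compound 4, of a size like that reached by compound 2 in an at least 4.0-fold lower number from compound 1 to compound 2 (0.60 log units; beyond the scatter) as the nearest guide. Compound 4 may still return only a limit. The expected move is an at least 3.3-fold lower number from compound 1 to compound 4 (0.52 log units; beyond the scatter) and it is held loosely. For compound 4 the estimate is 30000 nM with an expected range from 6000 nM to 100000 nM on this reading.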

Compound 4, concentration for 50% growth inhibition: 10000 nM
Compound 4: the middle estimate sits 3.0-fold (0.48 log units) above what was measured; measured number inside the range.
By their numbers in this assay, from the lowest: compound 4; then compounds 2 and 3 (each within the scatter of the next). At a limit, above all of these: compound 1.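

In this assay the place on a double-bonded chain carbon bound to a double-bonded chain carbon proves open to change, with 2,3-dichlorophenyl in place of 2,4,6-trihydroxyphenyl giving an at least 10-fold lower number from compound 1 to compound 4 (1.00 log units; beyond the scatter). This is the first step shown outside the group on the sulfur, and it indicates that the 2,4,6-trihydroxyphenyl group is not needed for a measurable growth inhibition value in this series: the entering 2,3-dichlorophenyl has no hydrogen-bond donors or acceptors. The step gives only a floor for the size of the change, and compound 1 holds a limit rather than a number: the limit of > 100000 nM in this assay, at which 1 of the 4 values shown sits.

This single swap removes the hydroxyl groups and adds the chlorines together, and compound 2 and compound 3 both keep the 2,4,6-trihydroxyphenyl group, leaving the separate parts of the change unresolved, along with whether it carries over to other groups on the sulfur. On these data alone, how an unsubstituted phenyl, or a phenyl bearing an amine or a carboxylic acid, would read at this place in this assay also remains open.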